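The source may report more compounds than this note shows. Statements on the series, on what has been measured and on what is new or still open speak of the compounds shown alone.

Working notes on the series. Compound 1 `CCOC(=O)[C@H](CCC(=O)O)NC(=O)c1ccc(CNc2nc3cc(N)cc(N)c3nc2-c2ccccc2)cc1` gives in a functional assay on ACHN cells (Homo sapiens) for inhibition, read by sulforhodamine B assay, with a stated time of 48 h (a higher number here means a weaker inhibitor of growth, a lower number a stronger inhibitor of growth), only < 100000 nM, which is a limit of the assay rather than a number (the limit of < 100000 nM in this assay, at which 1 of the 3 values shown sits). Compound 2 `COc1ccc(CNc2nc3cc(N)cc(N)c3nc2-c2ccccc2)cc1OC` gives 13800 nM in this assay. Compound 3 `COc1cc(CNc2nc3cc(N)cc(N)c3nc2-c2ccccc2)cc(OC)c1OC` gives 5370 nM in this assay. Among the two plain numbers, compound 2 stands highest; its nearest neighbour is compound 3, reached by methoxy in place of hydrogen on an aromatic carbon, with a 2.6-fold lower number from compound 2 to compound 3 (0.41 log units; beyond the scatter), a modest step beyond the scatter.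

Compound 4 `COc1ccc(CNc2nc3cc(N)cc(N)c3nc2-c2ccccc2)cc1` has not yet been measured. It differs from compound 2 by hydrogen in place of methoxy on an aromatic carbon. For the measured compounds named here, the only measured step that bears on this change is the one in which a methoxy is gained, a 2.6-fold lower number from compound 2 to compound 3 (0.41 log units; beyond the scatter); the change to compound 4 is the reverse in kind, a methoxy lost, though at a different aromatic carbon than the one compound 3 gains, so the measured step is only a loose guide. On that basis a modest rise in the number is expected, and the step from compound 2 to compound 4 in this assay is estimated as a 1.8-fold higher number from compound 2 to compound 4 (0.26 log units; within the scatter). Compound 4 is therefore expected to give about 25000 nM, within a range from 8000 nM to 80000 nM.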

Compound 4, concentration for 50% growth inhibition: 14800 nM
Estimate against measurement, compound 4: 1.7-fold (0.23 log units) above; the measured number falls inside the stated range.
By their numbers in this assay, from the lowest: compound 3; then compounds 2 and 4 (each within the scatter of the next).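

Replacing methoxy with hydrogen at this aromatic carbon, ortho to a methoxy group and meta to a large group, gives a 1.1-fold higher number from compound 2 to compound 4 (0.03 log units; within the scatter) in this assay, so the 3,4-dimethoxyphenyl of compound 2 and the 4-methoxyphenyl of compound 4 cannot be told apart in this read-out. The earlier step, a 2.6-fold lower number from compound 2 to compound 3 (0.41 log units; beyond the scatter), gained a methoxy at a different aromatic carbon of the same ring, so in these compounds a single methoxy change is beyond the scatter at one carbon and within it at the other, and methoxy changes on this ring cannot be treated as interchangeable. No available evidence bears on this result.

The compounds shown leave open whether a group other than methoxy at this aromatic carbon, such as a hydroxyl, an amine or a chlorine, would move the number beyond the scatter in this assay. They also leave open what happens when the remaining methoxy of compound 4 gives way to hydrogen or to a longer chain such as an ethoxy or propoxy group.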